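Removing the cyclopropylmethoxy group from compound 1

The source may hold more compounds than are shown below. What is called first, only, known or untested is meant among the compounds shown, and "the series" means these compounds.

Compound 1 `Oc1nc2nonc2nc1Nc1ccc(OCC2CC2)c(C(F)(F)F)c1` gives 1800 nM in an assay on mitochondria from L6 cells (Rattus norvegicus) for activation, with a stated time of 90 min (on this read-out higher numbers stand for an effect only at larger amounts of compound and lower numbers for an effect already at smaller amounts), the lowest of the three numbers available. Compound 2 `CCCCCCc1ccc(Nc2nc3nonc3nc2O)cc1` gives 4700 nM in this assay, and compound 3 `CCc1ccc(Nc2nc3nonc3nc2O)c(F)c1` gives 6700 nM; both stand beyond the scatter above compound 1. Compound 4 `Oc1nc2nonc2nc1Nc1cccc(C(F)(F)F)c1` has not been measured. It differs from compound 1 in one place: hydrogen in place of cyclopropylmethoxy on an aromatic carbon. Going by the values given here, no pair among the measured compounds shows this change, so its size is uncertain. Among the compounds with values here, since the cyclopropylmethoxy group is the only feature setting compound 1 apart from the other measured compounds, its removal is expected to cost activity; the step of a 3.1-fold higher number from compound 1 to compound 4 (0.49 log units; beyond the scatter) is estimated as a loss beyond the scatter. Compound 4 is expected near 5500 nM, within 2000 nM to 15000 nM.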

Compound 4, half-maximal effective concentration: 13300 nM
Beside the measured number, compound 4's estimate is 2.4-fold (0.38 log units) below it, and the stated range covers the measured number.
By their numbers in this assay, from the lowest: compound 1; then compounds 2, 3 and 4 (each within the scatter of the next, the first and the last beyond it).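

In this assay, going by these compounds alone, the change to hydrogen on the aromatic carbon ortho to the trifluoromethyl group gives a 7.4-fold higher number from compound 1 to compound 4 (0.87 log units; beyond the scatter) and provides the first one-place step. With the trifluoromethyl group held constant, activity at this position depends on the cyclopropylmethoxy group. No measurement bears on the reason for this loss. The compounds shown leave open whether the oxygen, the three-membered ring or the group's size matters. A methoxy group, a longer alkoxy chain or an amine at this carbon would help separate these.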